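A few compounds are considered here, and "the series" means these few. Any claim that something is new, unique, unknown or untested is made for them only; others in the source may bear on it.

The shared core is that of compound 1 `O=C(Nc1cc2nc(C3CCCCC3)[nH]c2cc1N1CCCC1)c1ccc(Br)cc1`. In an ADME assay on Vero cells (Chlorocebus sabaeus) for cytotoxicity, read by resazurin assay, with a stated time of 3 days (a lower number here means a stronger inhibitor, a higher number a weaker inhibitor), compound 1 gives > 100 ug/mL, which is a limit of the assay and not a number. Compound 2 `O=C(Nc1cc2nc(C3CCCCC3)[nH]c2cc1N1CCCC1)c1ccccc1` carries hydrogen in place of bromo on an aromatic carbon. In this assay compound 2 gives > 100 ug/mL, likewise a limit. The step that the two limits leave unreadable from compound 1 to compound 2 is therefore not sizable. For the measured compounds named here, both values sit at the limit of > 100 ug/mL in this assay, at which 2 of the 2 values shown sit, so compound 2 stands at the limit, and the one further value in hand is a limit as well. Compound 3 `COCCOC(=O)Nc1cc2nc(C3CCCCC3)[nH]c2cc1N1CCCC1` carries 2-methoxyethoxy in place of phenyl on a carbonyl carbon. Going by the values given here, no measured step touches this kind of change, and the single step available is unreadable, so nothing beyond a continued limit is expected in this assay. The estimate for compound 3 is 100 ug/mL, within 50 ug/mL to 200 ug/mL. The step of a number no higher from compound 2 to compound 3 (the limit leaves the size open) is expected to remain unreadable at the limit.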

Compound 3, half-maximal inhibitory concentration: > 100 ug/mL
Compound 3: no number, only a limit (the forecaster's own chance of this, stated with the estimate: 80%); the middle value sits exactly at the limit.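

In this assay compound 3 gives > 100 ug/mL, a limit of the assay and not a number. No step among compound 1, compound 2 and compound 3 can be read: the limit of > 100 ug/mL in this assay, at which 3 of the 3 values shown sit.

The compounds shown leave open at what concentration any of them turns cytotoxic, and whether the group on the carbonyl carbon alters that.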